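A few compounds are considered here, and "the series" means these few. Any claim that something is new, unique, unknown or untested is made for them only; others in the source may bear on it.

The measured compounds in an ADME assay on microsomes from liver (Homo sapiens) for metabolic stability, read by LC-MS, with a stated time of 10 min, tested at 0.5 uM; on this read-out higher numbers stand for a more stable compound and lower numbers for a less stable compound:

compound 1 `c1cnc2c(c1)CN[C@H](CN(CCCN1CCNCC1)[C@H]1CCCc3cccnc31)C2` gives 100%
compound 2 `c1ccc2c(c1)CN[C@@H](CN(CCCCN1CCNCC1)[C@H]1CCCc3cccnc31)C2` gives 82%
compound 3 `c1cnc2c(c1)CCC[C@@H]2N(CCCN1CCNCC1)Cc1cc2ccccc2cn1` gives 66%

Compound 2 stands second highest of the three numbers; compound 1 lies higher and compound 3 lies lower, each beyond the scatter. Among the measured compounds shown here, the only step between compounds that differ in one place is a number 34 percentage points lower from compound 1 to compound 3 (beyond the scatter), a large drop that concerns the group on the saturated chain carbon bound to the amine nitrogen, not the end of the chain. Compound 4 `NC(=O)N1CCN(CCCN(C[C@H]2Cc3ccccc3CN2)[C@H]2CCCc3cccnc32)CC1` differs from compound 2 by 4-carbamoylpiperazin-1-yl in place of (piperazin-1-yl)methyl on a saturated chain carbon, three bonds along the chain from an amine nitrogen. For the measured compounds named here, no measured step touches that part of the molecule; compounds 1 and 2 differ both in a ring and in the length of the chain, so their gap cannot be read as the effect of the chain alone. With nothing in the data pointing to a fall, the step expected from this change is a number 3 percentage points higher from compound 2 to compound 4 (within the scatter), within or near the scatter. The estimate for compound 4 in this assay is 85%, between 65% and 100%.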

Compound 4, percent of the compound remaining: 79%
Estimate against measurement, compound 4: 6 percentage points above; low and high end bracket the measured number.
By their numbers in this assay, from the lowest: compound 3; then compounds 4 and 2 (each within the scatter of the next); then compound 1.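

In this assay, among the compounds shown here, the first step at this end of the molecule, 4-carbamoylpiperazin-1-yl in place of (piperazin-1-yl)methyl, is a number 3 percentage points lower from compound 2 to compound 4 (within the scatter) and so does not separate the two compounds. For the compounds shown here, this position, on a saturated chain carbon, three bonds along the chain from an amine nitrogen, therefore accepts this change on the core of compound 2, whereas the only earlier step, a number 34 percentage points lower from compound 1 to compound 3 (beyond the scatter), concerned a different group. The data give no reason for this result.

On these data alone, whether the same holds on the cores of compound 1 or compound 3 remains open, as a single pair cannot show this. As far as these compounds go, it also remains open how an acetyl group or a methylsulfonyl group on the piperazine nitrogen, or a carboxylic acid at the chain end, would read here.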